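Swapping the pyridylmethyl-methylamine for a benzylamine

The source may hold more compounds than are shown below. What is called first, only, known or untested is meant among the compounds shown, and "the series" means these compounds.

Of the compounds shown here, three sharing one core have been measured in an assay on isolated protein for binding affinity to Gonadotropin-releasing hormone receptor (Homo sapiens); on this read-out higher numbers stand for weaker inhibition and lower numbers for stronger inhibition. Compound 1 `COc1cccc(-c2c(C)n(Cc3ccccc3F)c3nc(C(C)(C)C)c(CN(C)C)n3c2=O)c1` gives 1700 nM. Compound 2 `COc1cccc(-c2c(C)n(Cc3ccccc3F)c3nc(C(C)(C)C)c(CN(C)Cc4ccccc4)n3c2=O)c1` gives 72 nM, and compound 3 `COc1cccc(-c2c(C)n(Cc3ccccc3F)c3nc(C(C)(C)C)c(CN(C)Cc4ccccn4)n3c2=O)c1` gives 11 nM. Compound 3 stands lowest of the three, with compound 2 nearest and compound 1 furthest; the steps were a 24-fold lower number from compound 1 to compound 2 (1.37 log units; beyond the scatter), a 150-fold lower number from compound 1 to compound 3 (2.19 log units; beyond the scatter) and a 6.5-fold lower number from compound 2 to compound 3 (0.82 log units; beyond the scatter).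

Compound 4 `COc1cccc(-c2c(C)n(Cc3ccccc3F)c3nc(C(C)(C)C)c(CNCc4ccccc4)n3c2=O)c1` has not yet been measured. It differs from compound 3 in one region: benzylamino in place of methyl((pyridin-2-yl)methyl)amino on a saturated chain carbon bound to an aromatic carbon. This change bundles two things: the pyridin-2-yl group becomes phenyl, and the methyl on the amine nitrogen becomes hydrogen. The first part is the reverse of the step from compound 2 to compound 3, which was modest, so a move back toward the number of compound 2 is expected. Within the data shown here, the second part, loss of the methyl on the nitrogen, has no counterpart among the measured compounds, which widens the uncertainty. Compound 4 is therefore expected to land near compound 2, at about 90 nM, within 25 nM to 350 nM, a step of an 8.2-fold higher number from compound 3 to compound 4 (0.91 log units; beyond the scatter) in this assay.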

Compound 4, inhibition constant: 240 nM
Beside the measured number, compound 4's estimate is 2.7-fold (0.43 log units) below it; measured number inside the range.
By their numbers in this assay, from the lowest: compound 3; then compound 2; then compound 4; then compound 1.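

Taking the methyl off the amine nitrogen while keeping the benzyl group is a single clean change, and it gives a 3.3-fold higher number from compound 2 to compound 4 (0.52 log units; beyond the scatter) in this assay, so this methyl contributes on its own. Even without the methyl, benzylamino still outperforms dimethylamino, with a 7.1-fold lower number from compound 1 to compound 4 (0.85 log units; beyond the scatter) on this read-out, so the benzyl group keeps much of its benefit at this position. The two-part change gives a 22-fold higher number from compound 3 to compound 4 (1.34 log units; beyond the scatter) overall, and both parts push the number the same way.

As far as these compounds go, whether the methyl counts for as much alongside pyridin-2-yl remains open, as does the result of an ethyl on the amine nitrogen. Nothing shown here explains why the methyl or the ring nitrogen of pyridin-2-yl matters.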